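Second methoxy on the aryl ring: expectation for compound 3

The source may hold more compounds than are shown below. What is called first, only, known or untested is meant among the compounds shown, and "the series" means these compounds.

In a functional assay on COLO 205 cells (Homo sapiens) for inhibition, read by sulforhodamine B assay, tested at 100 uM (on this read-out higher numbers stand for more inhibition of growth at the one concentration tested and lower numbers for less inhibition of growth), compound 1 `CC(=O)N1N=C(c2ccc(OCc3cn(Cc4ccc([N+](=O)[O-])cc4)nn3)cc2)CC1c1ccccc1` gives 55% and compound 2 `COc1ccc(C2CC(c3ccc(OCc4cn(Cc5ccc([N+](=O)[O-])cc5)nn4)cc3)=NN2C(C)=O)cc1` gives 37%; compound 2 is the lower of the two numbers shown. Compound 3 `COc1ccc(C2CC(c3ccc(OCc4cn(Cc5ccc([N+](=O)[O-])cc5)nn4)cc3)=NN2C(C)=O)cc1OC` differs from compound 2 by methoxy in place of hydrogen on an aromatic carbon. For the measured compounds named here, the only measured step that bears on this change is a number 18 percentage points lower from compound 1 to compound 2 (beyond the scatter), a modest loss on adding a first methoxy to the same ring. Given a number 18 percentage points lower from compound 1 to compound 2 (beyond the scatter), a further decrease of similar or smaller size is expected, though a second methoxy need not repeat it fully. Compound 3 is expected at 28%, range 12% to 48%, meaning a number 9 percentage points lower from compound 2 to compound 3 (within the scatter).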

Compound 3, percent growth inhibition at one concentration: 38%
For compound 3 the middle estimate is 10 percentage points below the measured one; the range from low to high includes it.
By their numbers in this assay, from the lowest: compounds 2 and 3 (each within the scatter of the next); then compound 1.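

In this assay, the 4-methoxyphenyl to 3,4-dimethoxyphenyl change gives a number 1 percentage points higher from compound 2 to compound 3 (within the scatter), so a methoxy at this place, ortho to a methoxy group, adds no loss beyond that seen with the first methoxy. Relative to the phenyl of compound 1, the loss remains, with a number 17 percentage points lower from compound 1 to compound 3 (beyond the scatter). Nothing available explains this flat second step.

Still open, going by these compounds, is whether the loss is specific to methoxy or would also follow from other groups on this ring, such as fluorine, hydroxy or an amine. On these data alone, the effect of a longer alkoxy chain, such as ethoxy, is also open.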